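The source may hold more compounds than are shown below. What is called first, only, known or untested is meant among the compounds shown, and "the series" means these compounds.

The measured compounds are:

Compound 1, `CCCCCC(=O)Nc1cc2nc(C3CCCCC3)[nH]c2cc1N1CCCC1`: > 100 ug/mL
Compound 2, `CCCCCC(=O)Nc1cc2nc(C3CCCCC3)[nH]c2cc1N(CC)CC`: "not determined" (no result reported)
Compound 3, `CN(C)c1cc2[nH]c(C3CCCCC3)nc2cc1NC(=O)OCc1ccccc1`: > 100 ug/mL

In an ADME assay on Vero cells (Chlorocebus sabaeus) for cytotoxicity, read by resazurin assay, with a stated time of 3 days (on this read-out higher numbers stand for weaker inhibition and lower numbers for stronger inhibition), compound 1 gives > 100 ug/mL, which is a limit of the assay and not a number. Compound 3 gives > 100 ug/mL in this assay, again a limit rather than a measured number. For compound 2 this assay holds no result at all; the entry reads "not determined" (no result reported). Compound 2 therefore stands nowhere on the numbers shown, and the only anchor is the limit of > 100 ug/mL in this assay, at which 2 of the 3 values shown sit.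

Compound 4, `CCCNC(=O)Nc1cc2nc(C3CCCCC3)[nH]c2cc1N(CC)CC`, is the compound still to be measured. It differs from compound 2 in one place: propylamino in place of pentyl on a carbonyl carbon. Among the measured compounds shown here, no measured pair shows what such a change does in this assay, so no size or direction of step can be read from the data; the two measured values both sit at the limit, and a step beyond the scatter is not expected. Compound 4 is expected to give about 100 ug/mL in this assay, with a range from 50 ug/mL to 200 ug/mL, most likely reported again as a limit.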

Compound 4, half-maximal inhibitory concentration: > 100 ug/mL
Compound 4: no number, only a limit; the forecaster's own chance of this, stated with the estimate: 75%; the middle value sits exactly at the limit.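

Compound 4 gives > 100 ug/mL in this assay, a limit and not a number, and compound 2 has no value to set against it, so no step can be read between them. The compounds shown leave open whether exchanging pentyl for propylamino changes cell toxicity at all.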